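The compounds below may be only part of what the source reports. "The series", "measured", "known", "first", "only" and "open" are said of these compounds alone.

In an assay on isolated protein for inhibition of glutathione S-transferase P (Homo sapiens), read by spectrophotometry, with a stated time of 3 min (on this read-out lower numbers stand for stronger inhibition and higher numbers for weaker inhibition), compound 1 `CO[C@H]1C=C(COC(C)=O)C(=O)[C@@H]2O[C@@](C)(OC)[C@](C)(OC)O[C@@H]12` gives 62700 nM. Compound 3 `CO[C@]1(C)O[C@H]2[C@@H](O)C=C(COC(C)=O)C(=O)[C@@H]2O[C@@]1(C)OC` carries hydroxy where compound 1 carries methoxy. In this assay compound 3 gives 82500 nM, and a 1.3-fold higher number from compound 1 to compound 3 (0.12 log units; within the scatter). Compound 2 `CO[C@]1(C)O[C@H]2[C@H](O)C=C(COC(C)=O)C(=O)[C@@H]2O[C@@]1(C)OC` is recorded in this assay only as a limit, > 100000 nM. The comparison an at least 1.2-fold lower number from compound 2 to compound 3 (0.08 log units; that floor lies within the scatter) rests on the limit of > 100000 nM in this assay, at which 1 of the 3 values shown sits, and on (the fact that compounds 2 and 3 differ only in the configuration as drawn). Compound 4 `CO[C@@H]1C=C(COC(C)=O)C(=O)[C@@H]2O[C@@](C)(OC)[C@](C)(OC)O[C@@H]12` differs from compound 2 by methyl in place of hydrogen on an oxygen on a saturated carbon. The same exchange, read in reverse through the step from compound 1 to compound 3, shifted the number only within the scatter, so in this assay the expected step is a number no higher from compound 2 to compound 4 (the limit leaves the size open), no larger than the scatter. Compound 4 is therefore estimated at 100000 nM, between 55000 nM and 200000 nM, and may again be reported only as a limit.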

Compound 4, half-maximal inhibitory concentration: > 100000 nM
Compound 4: a limit, no number; the forecaster's own chance of this, stated with the estimate: 50%; the middle value sits exactly at the limit.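

Compound 4 is recorded only as a limit, > 100000 nM, in this assay. The methoxy pair now gives an at least 1.5-fold higher number from compound 1 to compound 4 (0.20 log units; that floor lies within the scatter), while the step from compound 2 to compound 4 cannot be read. In both the hydroxy and the methoxy pair, the compound drawn R at this saturated ring carbon is the one at the limit, and the methoxy step rests on configuration alone: the fact that compounds 1 and 4 differ only in the configuration as drawn

On these data alone, how far compound 2 and compound 4 actually lie from compound 1 and compound 3 stays open. So does how an amine or a longer chain at this place would read.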